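The compounds below may be only part of what the source reports. "The series", "measured", "known", "first", "only" and "open" are said of these compounds alone.

Measured so far:
compound 1 `Clc1cccc(-c2cc(-c3ccc(Cl)o3)cc(-c3cccs3)n2)c1` — 42%
compound 2 `Clc1ccc(-c2cc(-c3cccnc3)nc(-c3ccsc3)c2)o1` — 0%

In an assay on isolated protein for inhibition of DNA topoisomerase 1 (Homo sapiens), tested at 100 uM (a higher number here means a stronger effect of the compound at the concentration tested, a lower number a weaker effect), compound 1 gives 42%, the higher of the two numbers recorded; compound 2 gives 0% in this assay, a number a long way lower, well beyond the usual scatter of repeated measurements. Among the compounds with values here, the two compounds differ in several places at once, so no single step between them has been isolated; the pair shows only that the series spans inactivity and moderate inhibition at the test concentration.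

Compound 3 `Clc1ccc(-c2cc(-c3cccs3)nc(-c3ccccc3Cl)c2)o1` is not yet measured. It keeps the core of compound 1 and all its substituents, and differs from compound 1 only in this way: 2-chlorophenyl in place of 3-chlorophenyl on an aromatic carbon. The two compounds have the same atoms joined differently, the chlorine simply moving on the phenyl group.

Nothing in the measured pair tells how this assay responds to moving a chlorine on the phenyl group. A shift of a chlorine within the same ring is expected to give a step from compound 1 to compound 3 of a number 12 percentage points lower from compound 1 to compound 3 (beyond the scatter), with no strong lean in either direction. Compound 3 is therefore estimated at 30% in this assay, with an expected range from 5% to 60%.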

Compound 3, a percentage reported as inhibition, at one concentration (the size of the read-out at that concentration, not a potency): 41.3%
Compound 3: middle estimate off by 11.3 percentage points, on the low side, and the stated range covers the measured number.
By their numbers in this assay, from the lowest: compound 2; then compounds 3 and 1 (each within the scatter of the next).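

In this assay, 2-chlorophenyl in place of 3-chlorophenyl, on the aromatic carbon next to the ring nitrogen, reads as a number 0.7 percentage points lower from compound 1 to compound 3 (within the scatter), so this assay does not separate the two chlorine placements on the phenyl group. Within the data shown here, this is the first step that isolates a single place, and it shows that, with the 5-chlorofuran-2-yl and thiophen-2-yl groups held constant, inhibition at the test concentration survives the chlorine's relocation within this ring. No measurement is available that would explain the flat response at this position.

Open questions are whether the chlorine is needed at all, which a plain phenyl group would address, and how this assay would respond to a 4-chlorophenyl group or to a phenyl group carrying an amine or a carboxylic acid. Compound 2, at 0%, still differs from compound 1 and compound 3 in several places, so the contributions of its pyridin-3-yl and thiophen-3-yl groups remain unassigned.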